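Swapping the pyridine group on the amide of compound 1

The source may report more compounds than this note shows. Statements on the series, on what has been measured and on what is new or still open speak of the compounds shown alone.

compound 1 `Cc1ccc(-c2cc(C(=O)Nc3ccc(Cl)nc3Cl)nn2-c2ccc3ccccc3n2)cc1` gives 12700 nM
compound 2 `COc1ncccc1NC(=O)c1cc(-c2ccc(C)cc2)n(-c2ccc3ccccc3n2)n1` gives 30200 nM

Both values come from a functional assay on MCF7 cells (Homo sapiens) for cytotoxicity, read by sulforhodamine B assay, with a stated time of 72 h; on this read-out lower numbers stand for stronger inhibition and higher numbers for weaker inhibition. Compound 1 has the lower number of the two, so it is the stronger inhibitor of this pair, and the gap to compound 2 lies beyond the usual scatter.

Compound 3 `Cc1ccc(-c2cc(C(=O)Nc3ncc(Br)cc3Br)nn2-c2ccc3ccccc3n2)cc1` keeps the core of compound 1 and changes only the group on an amide-type nitrogen: 3,5-dibromopyridin-2-yl in place of 2,6-dichloropyridin-3-yl on an amide-type nitrogen. Among the compounds with values here, one measured step bears on this place, a 2.4-fold higher number from compound 1 to compound 2 (0.38 log units; beyond the scatter), where 2-methoxypyridin-3-yl takes the place of 2,6-dichloropyridin-3-yl. That step is modest, and it shows that the number in this assay can move when this group changes. Within the data shown here, no measured compound carries the 3,5-dibromopyridin-2-yl group, so the data give no firm direction. A step no larger than the measured one is expected, with a slight lean towards a higher number. The expected change is a 1.3-fold higher number from compound 1 to compound 3 (0.10 log units; within the scatter), and it may well stay within the scatter. For compound 3 the estimate is 16000 nM, with 6500 nM to 38000 nM as the expected range.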

Compound 3, half-maximal inhibitory concentration: 16900 nM
The estimate for compound 3 lay 1.1-fold (0.02 log units) below the measured number, within the range that was stated.
By their numbers in this assay, from the lowest: compounds 1, 3 and 2 (each within the scatter of the next, the first and the last beyond it).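

Putting 3,5-dibromopyridin-2-yl in place of 2,6-dichloropyridin-3-yl on the amide-type nitrogen gives a 1.3-fold higher number from compound 1 to compound 3 (0.12 log units; within the scatter) in this assay and so cannot be told apart from repeated-measurement scatter, even though chlorine gives way to bromine and the two pyridine groups carry different numbering in their names. Set against the methoxy compound, the new group gives a 1.8-fold lower number from compound 2 to compound 3 (0.25 log units; within the scatter) and this too stays within the scatter. Compound 3 therefore sits within the scatter of both other compounds while compound 1 and compound 2 remain apart beyond it, which means the pyridine swaps at this place have so far produced only small steps, and nothing available explains why these groups give such close numbers.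

From the compounds shown here alone, all three groups at this place are substituted pyridines, so it stays open how the number would respond to an unsubstituted phenyl ring, or to a pyridine bearing an amine or a carboxylic acid. Whether a longer chain between the amide-type nitrogen and the ring would shift the number well beyond the scatter also remains unanswered by these compounds.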